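Removing the trifluoromethyl from the amide aryl group

The source may hold more compounds than are shown below. What is called first, only, known or untested is meant among the compounds shown, and "the series" means these compounds.

Measured compounds and their values:
compound 1, `COc1ccc(-n2nc(C(N)=O)nc2-c2cc(OC)c(OC)c(OC)c2)cc1`, 40%
compound 2, `COc1ccc(-n2nc(C(=O)Nc3ccccc3OC)nc2-c2cc(OC)c(OC)c(OC)c2)cc1`, 52%
compound 3, `COc1ccc(-n2nc(C(=O)Nc3ccc(C(F)(F)F)cc3)nc2-c2cc(OC)c(OC)c(OC)c2)cc1`, 48%

The three compounds share one core and differ only at the amide-type nitrogen. In a functional assay on the whole organism for inhibition, with Rattus norvegicus as the target, read by paw edema, with stated times of 30 min and 1 h, at a dose of 0.28 mmol/kg by the oral route (on this read-out higher numbers stand for more inhibition at the one dose given (going by the name of the read-out) and lower numbers for less inhibition), compound 1 gives 40%, compound 2 gives 52% and compound 3 gives 48%. Compound 3 stands second highest of the three numbers, but its gaps to both neighbours lie within the usual scatter, so no order among them can be claimed. The step of a number 12 percentage points higher from compound 1 to compound 2 (beyond the scatter) is the only one beyond the scatter; the steps of a number 8 percentage points higher from compound 1 to compound 3 (within the scatter) and a number 4 percentage points lower from compound 2 to compound 3 (within the scatter) are not.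

Compound 4, `COc1ccc(-n2nc(C(=O)Nc3ccccc3)nc2-c2cc(OC)c(OC)c(OC)c2)cc1`, has not yet been measured. It differs from compound 3 by hydrogen in place of trifluoromethyl on an aromatic carbon. The measured steps that bear on this are those changing the aryl group on the amide-type nitrogen, a number 4 percentage points lower from compound 2 to compound 3 (within the scatter) and a number 8 percentage points higher from compound 1 to compound 3 (within the scatter), both within the scatter. Since swapping whole aryl groups left the read-out essentially unchanged, removing the trifluoromethyl is expected to give a step of about a number 2 percentage points lower from compound 3 to compound 4 (within the scatter) in this assay, not beyond the scatter. Compound 4 is therefore estimated at 46%, with a range from 36% to 56%.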

Compound 4, a percentage reported as inhibition, in the whole organism at one dose (the size of the read-out at that dose, not a potency): 45%
Compound 4: middle estimate off by 1 percentage points, on the high side; the range from low to high includes it.
By their numbers in this assay, from the lowest: compounds 1, 4, 3 and 2 (each within the scatter of the next, the first and the last beyond it).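

In this assay, removing the trifluoromethyl gives a number 3 percentage points lower from compound 3 to compound 4 (within the scatter) and so does not measurably alter the read-out at this position. The plain phenyl amide also gives a number 7 percentage points lower from compound 2 to compound 4 (within the scatter) and a number 5 percentage points higher from compound 1 to compound 4 (within the scatter) and therefore cannot be separated from either neighbour, although a number 12 percentage points higher from compound 1 to compound 2 (beyond the scatter) does separate the two neighbours from each other. No other measurement accompanies these numbers, so nothing here explains them.

Going by these compounds, what remains open is whether any group on this phenyl ring can shift the read-out beyond the scatter relative to compound 4 as the reference. An amine or a carboxylic acid on the ring, or a longer chain in place of the phenyl on the amide nitrogen, would test this.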